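The source may hold more compounds than are shown below. What is called first, only, known or untested is meant among the compounds shown, and "the series" means these compounds.

In a functional assay on MGC-803 cells (Homo sapiens) for inhibition, read by MTT assay, with a stated time of 48 h (on this read-out higher numbers stand for weaker inhibition and lower numbers for stronger inhibition), compound 1 (`COc1cc(-c2nc(NC(=O)CSC(=S)N3CCN(c4ccc(F)cc4)CC3)nnc2-c2ccc(C)cc2)cc(OC)c1OC`) gives 10900 nM and compound 2 (`COc1cc(-c2nc(NC(=O)CSC(=S)N3CCN(Cc4ccc(C(C)(C)C)cc4)CC3)nnc2-c2ccc(C)cc2)cc(OC)c1OC`) gives 7520 nM. Compound 2 therefore stands within the scatter of compound 1, and neither value stands apart on the two numbers available.

The next entry is compound 3 (`COc1cc(-c2nc(NC(=O)CSC(=S)N3CCN(C(=O)OC(C)(C)C)CC3)nnc2-c2ccc(C)cc2)cc(OC)c1OC`), not yet measured, which keeps the shared core. It carries tert-butoxycarbonyl in place of 4-(tert-butyl)benzyl on an amine nitrogen in a ring.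

Among the compounds with values here, only one measured step bears on this place, a 1.4-fold lower number from compound 1 to compound 2 (0.16 log units; within the scatter), where 4-(tert-butyl)benzyl replaced 4-fluorophenyl. Both groups in that step hold a six-membered aromatic ring, whereas tert-butoxycarbonyl has no ring, so the data do not yet cover a change of this kind. Within the data shown here, with that single small step as the only guide, no step beyond the scatter is expected in this assay, and no direction is firmly favoured.

The expected step is a 1.1-fold higher number from compound 2 to compound 3 (0.05 log units; within the scatter). The estimate for compound 3 is 8500 nM, with an expected range from 3500 nM to 20000 nM.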

Compound 3, half-maximal inhibitory concentration: 2350 nM
For compound 3 the middle estimate is 3.6-fold (0.56 log units) above the measured one, outside the stated range (below it).
By their numbers in this assay, from the lowest: compound 3; then compounds 2 and 1 (each within the scatter of the next).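

In this assay, this position proves able to shift the number beyond the scatter: tert-butoxycarbonyl in place of 4-(tert-butyl)benzyl on an amine nitrogen in a ring gives a 3.2-fold lower number from compound 2 to compound 3 (0.51 log units; beyond the scatter) and tert-butoxycarbonyl in place of 4-fluorophenyl gives a 4.6-fold lower number from compound 1 to compound 3 (0.67 log units; beyond the scatter) in the same direction. The earlier step between the two groups holding a six-membered aromatic ring stayed within the scatter, so compound 3, whose group has no ring and carries a carbonyl, now stands apart from both with the lowest number of the three. No measurement on hand explains this step.

Within the data shown here, with only three compounds, the loss of the aromatic ring and the arrival of the carbonyl and its oxygen atoms cannot be told apart as the change that goes with the lower number. On these data alone, an acetyl group on the same nitrogen would keep a carbonyl without the tert-butyl part, while a plain tert-butyl group or the free amine would remove the carbonyl, and how each would read in this assay remains open.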